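Changing the Amide Substituent on a Core With No Measured Activity

The source may hold more compounds than are shown below. What is called first, only, known or untested is meant among the compounds shown, and "the series" means these compounds.

Compound 1 `COc1ccc2c(=O)c(/C=C/C(=O)Nc3ccccc3)coc2c1` was tested in a functional assay on L02 cells (Homo sapiens) for inhibition, read by MTT assay, with a stated time of 48 h; on this read-out higher numbers stand for weaker inhibition and lower numbers for stronger inhibition. In this assay compound 1 gives > 200000 nM, which is a limit of the assay rather than a number. Two related compounds were examined in the same way. Compound 2 `Cc1ccccc1NC(=O)/C=C/c1coc2cc(O)ccc2c1=O` gives > 200000 nM, again only a limit. Compound 3 `O=C(/C=C/c1coc2cc(O)ccc2c1=O)NCc1ccccc1` gives > 200000 nM, also a limit. The only single change among these three, a step that the two limits leave unreadable from compound 2 to compound 3, has no readable size because the limit of > 200000 nM in this assay, at which 3 of the 3 values shown sit, hides any difference between its two ends.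

Compound 4 `COc1ccc2c(=O)c(/C=C/C(=O)NCc3ccc(C)cc3)coc2c1` differs from compound 1 by 4-methylbenzyl in place of phenyl on an amide-type nitrogen. For the measured compounds named here, no measured step resembles this change, and the one step that exists gives no size at all. The three measured compounds, all resting at the same limit, give no reason to expect compound 4 to behave differently, so a step from compound 1 to compound 4 of a step that the limit leaves unreadable from compound 1 to compound 4 is expected, which is no step beyond the scatter. For compound 4 the expected value in this assay is therefore 300000 nM, within a range from 120000 nM to 800000 nM, most likely reported again only as a limit.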

Compound 4, half-maximal inhibitory concentration: > 200000 nM
Compound 4 ended at the assay's limit; the forecaster's own chance of this, stated with the estimate: 85%; the middle value is on the limit's open side.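

No size can be read for the change from compound 1 to compound 4, because both results rest on the same boundary: the limit of > 200000 nM in this assay, at which 4 of the 4 values shown sit.

The compounds shown leave open whether any amide substituent on these structures can give a measurable number in this assay.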